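Two Chlorines on the Phenyl of Compound 1

The compounds below may be only part of what the source reports. "The series", "measured", "known", "first", "only" and "open" are said of these compounds alone.

In a functional assay on Ehrlich cells (Mus musculus) for cytotoxicity, read by trypan blue exclusion, with a stated time of 2 h, tested at 25 ug/mL (on this read-out higher numbers stand for a stronger effect at the one concentration tested and lower numbers for a weaker effect), compound 1 `N#CC1=C(N)N(c2ccc(S(N)(=O)=O)cc2)C2=C(CCCC2)C1c1ccccc1` gives 10%, the second highest of three numbers. Its nearest is compound 3 `N#CC1=C(N)N(c2ccc(S(N)(=O)=O)cc2)C2=C(CCCC2)C1c1ccc([N+](=O)[O-])cc1`, which gives 5%; its furthest is compound 2 `COc1ccccc1C1C(C#N)=C(N)N(c2ccc(S(N)(=O)=O)cc2)C2=C1CCCC2`, which gives 40%. Compound 4 `N#CC1=C(N)N(c2ccc(S(N)(=O)=O)cc2)C2=C(CCCC2)C1c1ccc(Cl)c(Cl)c1` is not yet measured and differs from compound 1 by 3,4-dichlorophenyl in place of phenyl on a saturated ring carbon. Three measured steps alter the same phenyl: a number 30 percentage points higher from compound 1 to compound 2 (beyond the scatter), a number 5 percentage points lower from compound 1 to compound 3 (within the scatter), and a number 35 percentage points lower from compound 2 to compound 3 (beyond the scatter). A methoxy on that phenyl raised the number modestly, while a nitro left it within the scatter, so no dramatic shift is expected from the two chlorines. Compound 4 is therefore expected to give 15%, between 5% and 40%, which means a number 5 percentage points higher from compound 1 to compound 4 (within the scatter).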

Compound 4, a percentage reported as activity, at one concentration (the size of the read-out at that concentration, not a potency): 40%
Estimate against measurement, compound 4: 25 percentage points below; the measured number falls inside the stated range.
By their numbers in this assay, from the lowest: compounds 3 and 1 (each within the scatter of the next); then compounds 2 and 4 (each within the scatter of the next).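

Placing 3,4-dichlorophenyl in place of phenyl on this saturated ring carbon gives a number 30 percentage points higher from compound 1 to compound 4 (beyond the scatter), so the 2-methoxyphenyl group is not the only replacement shown to lift the number. The other two comparisons give a number 35 percentage points higher from compound 3 to compound 4 (beyond the scatter) and no change at the digits printed from compound 2 to compound 4 (within the scatter), which sets two differently substituted phenyls level and leaves 4-nitrophenyl well short of them. Nothing measured here explains these differences.

It remains open whether both chlorines are needed, since a single chlorine is not among the compounds shown. As far as these compounds go, an amine or a carboxylic acid on this phenyl also remains untested among them.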